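Swapping 4-fluorophenyl for 2-chlorophenyl on the shared core

This account rests on a few compounds, and the source may have more. Where it says the series, first, only, none or still open, it means among the compounds named here.

In an ADME assay on BHK-21 cells (Mesocricetus auratus) for cytotoxicity, read by MTT assay, with a stated time of 72 h (on this read-out lower numbers stand for higher toxicity in this test and higher numbers for lower toxicity in this test), compound 1 `Cc1ccccc1C1CC(c2ccc(OCc3ccccc3)cc2)=NN1c1ccc(S(N)(=O)=O)cc1` gives 20000 nM, compound 2 `NS(=O)(=O)c1ccc(N2N=C(c3ccc(OCc4ccccc4)cc3)CC2c2ccccc2)cc1` gives 80000 nM and compound 3 `NS(=O)(=O)c1ccc(N2N=C(c3ccc(OCc4ccccc4)cc3)CC2c2ccc(F)cc2)cc1` gives 60000 nM. Compound 3 thus sits together with compound 2 at the upper end of these three numbers. The gap between that pair is a 1.3-fold lower number from compound 2 to compound 3 (0.12 log units; within the scatter), whereas the wider gap is a 3.0-fold higher number from compound 1 to compound 3 (0.48 log units; beyond the scatter).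

Compound 4 `NS(=O)(=O)c1ccc(N2N=C(c3ccc(OCc4ccccc4)cc3)CC2c2ccccc2Cl)cc1` has not yet been measured. It carries 2-chlorophenyl in place of 4-fluorophenyl on a saturated ring carbon.

For the measured compounds named here, the closest precedent is the 2-methylphenyl group of compound 1, the only measured compound with a group at that place on this ring other than hydrogen or fluoro. Its other step is a 4.0-fold higher number from compound 1 to compound 2 (0.60 log units; beyond the scatter). Whether 2-chlorophenyl follows 2-methylphenyl cannot be told from these data, but a modest fall toward compound 1 in this assay is expected. The expected step is a 2.4-fold lower number from compound 3 to compound 4 (0.38 log units; beyond the scatter). For compound 4 the estimated value is 25000 nM, within an expected range of 10000 nM to 60000 nM.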

Compound 4, half-maximal cytotoxic concentration: 12000 nM
For compound 4 the middle estimate is 2.1-fold (0.32 log units) above the measured one, within the range that was stated.
By their numbers in this assay, from the lowest: compounds 4 and 1 (each within the scatter of the next); then compounds 3 and 2 (each within the scatter of the next).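

In this assay, the fluoro of compound 3 had left the number within the scatter of the unsubstituted phenyl (in a 1.3-fold lower number from compound 2 to compound 3 (0.12 log units; within the scatter)), but a halogen at this saturated ring carbon's phenyl group is not neutral as such: chloro in place of hydrogen gives a 6.7-fold lower number from compound 2 to compound 4 (0.82 log units; beyond the scatter) and 2-chlorophenyl in place of 4-fluorophenyl gives a 5.0-fold lower number from compound 3 to compound 4 (0.70 log units; beyond the scatter). Chloro in place of methyl gives a 1.7-fold lower number from compound 1 to compound 4 (0.22 log units; within the scatter), so 2-chlorophenyl and 2-methylphenyl read alike, and among these four compounds, with none going against it, compounds 1 and 4 form a low pair apart from compounds 2 and 3. The data shown offer no explanation for this split.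

From the compounds shown here alone, whether the split follows the place of the group on the phenyl ring or the group itself stays open, as 4-chlorophenyl would be needed to separate the two. Going by these compounds, how 2-methoxyphenyl or 2-aminophenyl would read at this carbon also remains unknown.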